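The compounds below may be only part of what the source reports. "The series", "measured", "known", "first", "only" and "open" are said of these compounds alone.

Measured so far in a functional assay (QGY7701 cells, Homo sapiens) for inhibition, read by MTT assay, with a stated time of 48 h; on this read-out lower numbers stand for stronger inhibition and higher numbers for weaker inhibition:
compound 1 `COc1ccc2c(=O)c(/C=C/C(=O)Nc3cc(C)ccc3C)coc2c1` — > 100000 nM, a limit of the assay rather than a number
compound 2 `COc1cccc(NC(=O)/C=C/c2coc3cc(OC)ccc3c2=O)c1` — 39100 nM
compound 3 `COc1ccc(CNC(=O)/C=C/c2coc3cc(OC)ccc3c2=O)cc1` — 15700 nM

Compound 3 holds the lowest of the two numbers shown; the nearest is compound 2, separated by a 2.5-fold lower number from compound 2 to compound 3 (0.40 log units; beyond the scatter). Because compound 1 sits only at a limit (the limit of > 100000 nM in this assay, at which 1 of the 3 values shown sits), the steps from it are bounds: an at least 2.5-fold lower number from compound 1 to compound 2 (0.40 log units; beyond the scatter) and an at least 6.3-fold lower number from compound 1 to compound 3 (0.80 log units; beyond the scatter).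

The next member is compound 4 `COc1ccc2c(=O)c(/C=C/C(=O)Nc3ccccc3OC)coc2c1`: 2-methoxyphenyl in place of 4-methoxybenzyl on an amide-type nitrogen. Among the compounds with values here, this reverses the kind of change seen in a 2.5-fold lower number from compound 2 to compound 3 (0.40 log units; beyond the scatter), where a methoxy-bearing phenyl on the amide nitrogen gave way to a methoxy-bearing benzyl and the number fell modestly; the methoxy group also changes its place on the ring, for which no measured pair exists. Within the data shown here, the only guide is compound 2, which carries a methoxyphenyl on the same nitrogen and gives 39100 nM. A modest rise back toward that number is therefore expected, with added uncertainty from the unsampled methoxy placement; the expected step is a 2.5-fold higher number from compound 3 to compound 4 (0.41 log units; beyond the scatter). Compound 4 is estimated at 40000 nM, within 12000 nM to 130000 nM.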

Compound 4, half-maximal inhibitory concentration: 17600 nM
Compound 4: middle estimate off by 2.3-fold (0.36 log units), on the high side; low and high end bracket the measured number.
By their numbers in this assay, from the lowest: compounds 3 and 4 (each within the scatter of the next); then compound 2. At a limit, above all of these: compound 1.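

In this assay, a methoxy-bearing phenyl attached directly to the amide-type nitrogen no longer stands apart from the benzyl group, with a 1.1-fold higher number from compound 3 to compound 4 (0.05 log units; within the scatter); the number of compound 2 therefore does not follow from the directly attached ring alone. The two methoxyphenyl isomers give the first measured read on the methoxy placement, with a 2.2-fold lower number from compound 2 to compound 4 (0.35 log units; beyond the scatter), so the 2-methoxyphenyl and 3-methoxyphenyl groups are not interchangeable at this nitrogen in this pair. Compound 1 sits at a limit, so an at least 5.6-fold lower number from compound 1 to compound 4 (0.75 log units; beyond the scatter) gives only a bound on replacing 2,5-dimethylphenyl with 2-methoxyphenyl: the limit of > 100000 nM in this assay, at which 1 of the 4 values shown sits.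

Open questions at this nitrogen include how a 4-methoxyphenyl or a 2-methoxybenzyl group would read, which would show whether the placement step holds across more of the methoxyphenyl set and on the benzyl side. Also open is how this assay would respond to a group without an aromatic ring, such as a longer alkyl chain, an amine or a carboxylic acid, and to any change in the shared core, which is the same in all the compounds shown.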